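Cyano for Fluoro on a Shared Hydroxamate Core

The compounds below may be only part of what the source reports. "The series", "measured", "known", "first", "only" and "open" are said of these compounds alone.

Three compounds sharing one core were measured in a functional assay on PC-3 cells (Homo sapiens) for inhibition, read by sulforhodamine B assay; on this read-out higher numbers stand for weaker inhibition of growth and lower numbers for stronger inhibition of growth. Compound 1 `O=C(CCC1=CCN(CCCc2ccc(Cl)cc2)C1=O)NO` gives 3480 nM. Compound 2 `CCOc1ccc(CCCN2CC=C(CCC(=O)NO)C2=O)cc1` gives 3480 nM. Compound 3 `O=C(CCC1=CCN(Cc2ccc(F)cc2)C1=O)NO` gives 5310 nM, a number that lies within the scatter of the values of compound 1 and compound 2, so none of the three can be called stronger or weaker than another. Within the data shown here, the single measured step, no change at the digits printed from compound 1 to compound 2 (within the scatter), is the only guide, and it concerns different groups on the aromatic ring. Compound 4 `N#Cc1ccc(CN2CC=C(CCC(=O)NO)C2=O)cc1` differs from compound 3 by cyano in place of fluoro on an aromatic carbon. Because no change at the digits printed from compound 1 to compound 2 (within the scatter) stayed flat, compound 4 is expected to show a 1.1-fold lower number from compound 3 to compound 4 (0.03 log units; within the scatter), nothing beyond the scatter. Compound 4 is therefore estimated at 5000 nM, with a range from 2000 nM to 12500 nM.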

Compound 4, concentration for 50% growth inhibition: > 10000 nM
Compound 4 ended at the assay's limit; the forecaster's own chance of this, stated with the estimate: 3%; middle value at least 2.0-fold (0.30 log units) away from the limit.
By their numbers in this assay, from the lowest: compounds 1, 2 and 3 (each within the scatter of the next). At a limit, above all of these: compound 4.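

In this assay compound 4 gives > 10000 nM, which is a limit of the assay and not a number. Cyano in place of fluoro on an aromatic carbon, para to a large group, gives an at least 1.8-fold higher number from compound 3 to compound 4 (0.27 log units; that floor lies within the scatter), so unlike the flat ethoxy for chloro step, this change has only a floor, and that floor does not by itself separate the two compounds. This is the only reading of its kind in the set: the limit of > 10000 nM in this assay, at which 1 of the 4 values shown sits.

The compounds shown leave open how an amine or a carboxylic acid would read at this same position. They also leave open whether cyano would read the same on the longer chain that compound 1 carries.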